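The source may hold more compounds than are shown below. What is called first, only, known or untested is meant among the compounds shown, and "the series" means these compounds.

Compound 1 `COC(=O)C1=C(C)N(C)C(=O)NC1c1ccsc1` gives 24% in an assay on membranes from CHO cells for displacement of a labelled ligand from adenosine receptor A1 (Homo sapiens), read by scintillation counting, with a stated time of 60 min, tested at 1 uM; on this read-out lower numbers stand for less inhibition and higher numbers for more inhibition at the one concentration tested (going by the name of the read-out). Compound 2 `CCOC(=O)C1=C(C)N(C)C(=O)NC1c1ccsc1` gives 32% in this assay, and the step of a number 8 percentage points higher from compound 1 to compound 2 (within the scatter) belongs to the change (methyl in place of hydrogen on a saturated chain carbon bound to an oxygen next to a carbonyl group). Compound 3 `CCSC(=O)C1=C(C)NC(=O)NC1c1ccco1` gives 6% in this assay; how its core differs from that of compound 1 is not broken down here. Compound 4 `CC1=C(C(=O)SC(C)C)C(c2ccco2)NC(=O)N1` has not yet been measured. It differs from compound 3 by methyl in place of hydrogen on a saturated chain carbon bound to a saturated chain carbon and a sulfur, the same kind of change as from compound 1 to compound 2, though not the same: there the place is a saturated chain carbon bound to an oxygen next to a carbonyl group, here a saturated chain carbon bound to a saturated chain carbon and a sulfur. Resting on a number 8 percentage points higher from compound 1 to compound 2 (within the scatter), a step of a number 6 percentage points higher from compound 3 to compound 4 (within the scatter) is expected. Compound 4 is therefore estimated at 12%, between 0% and 30%.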

Compound 4, a percentage reported as inhibition, at one concentration (the size of the read-out at that concentration, not a potency): 5%
Estimate against measurement, compound 4: 7 percentage points above, within the range that was stated.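

The step in this assay is a number 1 percentage points lower from compound 3 to compound 4 (within the scatter). Set beside the earlier step, the two cores do not separate: the same change on two cores in this assay, a number 8 percentage points higher (within the scatter) from compound 1 to compound 2 and a number 1 percentage points lower (within the scatter) from compound 3 to compound 4, 9 percentage points apart, within the scatter of two such steps

This shows that, on these two cores, methyl in place of hydrogen gives no step beyond the scatter, but it does not establish a fixed size for the change, and the two places differ, one carbon being bound to an oxygen next to a carbonyl group and the other to a saturated chain carbon and a sulfur.

The compounds shown leave open how a longer chain, a benzyl group or a chain carrying an amine or a carboxylic acid would read in place of the isopropyl. They also leave open how (ethylsulfanyl)carbonyl would read on the core of compound 1.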